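This account rests on a few compounds, and the source may have more. Where it says the series, first, only, none or still open, it means among the compounds named here.

Of the compounds shown here, three of a shared core have been measured in an assay on membranes from CHO cells for displacement of a labelled ligand from adenosine receptor A1 (Homo sapiens), read by scintillation counting, with a stated time of 60 min, tested at 1 uM; on this read-out higher numbers stand for more inhibition at the one concentration tested (going by the name of the read-out) and lower numbers for less inhibition. Compound 1, `CC1=C(C(=O)C2CC2)C(c2ccco2)NC(=O)N1`, gives 2%. Compound 2, `CC1=C(C(=O)NC(C)C)C(c2ccco2)NC(=O)N1`, gives 3%, and its number differs from that of compound 1 and from that of compound 3 only within the scatter. Compound 3, `CC1=C(C(=O)NC(C)C)C(c2ccsc2)NC(=O)N1`, gives 8%. Within the data shown here, the step of a number 1 percentage points higher from compound 1 to compound 2 (within the scatter) changes the group on the carbonyl carbon, and the step of a number 5 percentage points higher from compound 2 to compound 3 (within the scatter) changes the group on the saturated ring carbon; neither moves the read-out beyond the scatter, and every number so far is small.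

Compound 4, `CC1=C(C(=O)SC(C)C)C(c2ccco2)NC(=O)N1`, is not yet measured. It differs from compound 2 by isopropylsulfanyl in place of isopropylamino on a carbonyl carbon. Among the measured compounds shown here, the one step that touches the same carbonyl carbon, the step from compound 1 to compound 2, was within the scatter, and no measured step reaches beyond it. Compound 4 is therefore expected to stay near compound 2, with a step of a number 1 percentage points higher from compound 2 to compound 4 (within the scatter) in this assay. For compound 4 the estimate is 4%, within -5% to 13%.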

Compound 4, a percentage reported as inhibition, at one concentration (the size of the read-out at that concentration, not a potency): 5%
The estimate for compound 4 lay 1 percentage points below the measured number; low and high end bracket the measured number.
By their numbers in this assay, from the lowest: compounds 1, 2, 4 and 3 (each within the scatter of the next).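

Isopropylsulfanyl in place of isopropylamino on a carbonyl carbon swaps a hydrogen-bond donor for a hydrogen-bond acceptor in the count of the group, and this assay shows a number 2 percentage points higher from compound 2 to compound 4 (within the scatter) for this change. Against cyclopropyl at the same place, the same group gives a number 3 percentage points higher from compound 1 to compound 4 (within the scatter) and so cyclopropyl, isopropylamino and isopropylsulfanyl on this carbonyl carbon all lie within the scatter of one another, with the nitrogen-to-sulfur exchange leaving the read-out where it was. Nothing measured here speaks to why the number stays small at this position.

Going by these compounds, whether a carboxylic acid, a primary amine or a longer chain on this carbonyl carbon would move the number beyond the scatter stays open. So does whether isopropylsulfanyl would read the same with thiophen-3-yl in place of furan-2-yl on the saturated ring carbon.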